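This account rests on a few compounds, and the source may have more. Where it says the series, first, only, none or still open, it means among the compounds named here.

Series notes. In an ADME assay on HepG2 cells (Homo sapiens) for cytotoxicity, read by luminescence, CellTiter-Glo and ATP content, with a stated time of 72 h (on this read-out higher numbers stand for an effect only at larger amounts of compound and lower numbers for an effect already at smaller amounts), compound 1 `COc1ccc(F)cc1CNCCCNc1ccnc2cc(CCc3ccccc3)ccc12` gives 4240 nM, the lowest of the three numbers shown; compound 2 `COc1cccc(CNCCCNc2ccnc3cc(Oc4ccccc4)ccc23)c1O` gives 6800 nM, which sits within the scatter of compound 1, while compound 3 `c1ccc(CCc2ccc3c(NCCCNCc4ccco4)ccnc3c2)cc1` gives 16000 nM. Within the data shown here, the only single-point step, a 3.8-fold higher number from compound 1 to compound 3 (0.58 log units; beyond the scatter), changes the group on a saturated chain carbon bound to an amine nitrogen. Compound 4 `COc1ccc(F)cc1CNCCCNc1ccnc2cc(Cc3cccc(C(F)(F)F)c3)ccc12` differs from compound 1 elsewhere: 3-(trifluoromethyl)phenyl in place of benzyl on a saturated chain carbon bound to an aromatic carbon. Among the measured compounds shown here, no measured step touches a saturated chain carbon bound to an aromatic carbon, and compound 2 differs from compound 1 in two places, so only its value stands beside that of compound 1. In this assay the step expected for compound 4 is a 1.1-fold higher number from compound 1 to compound 4 (0.03 log units; within the scatter), nothing beyond the scatter. Compound 4 is estimated at 4500 nM, with a range from 1500 nM to 13000 nM.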

Compound 4, half-maximal effective concentration: 440 nM
Beside the measured number, compound 4's estimate is 10-fold (1.01 log units) above it; the whole stated range lies above it.
By their numbers in this assay, from the lowest: compound 4; then compounds 1 and 2 (each within the scatter of the next); then compound 3.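

At a saturated chain carbon bound to an aromatic carbon, 3-(trifluoromethyl)phenyl in place of benzyl gives a 9.6-fold lower number from compound 1 to compound 4 (0.98 log units; beyond the scatter) in this assay. This position therefore moves the number beyond the scatter, and in the opposite direction to the change on a saturated chain carbon bound to an amine nitrogen, a 3.8-fold higher number from compound 1 to compound 3 (0.58 log units; beyond the scatter). Nothing at hand bears on why the number falls.

Read as phenethyl to 3-(trifluoromethyl)benzyl, the change alters both chain and ring substituent, so their shares remain open. Unsubstituted benzyl or chlorobenzyl here would help separate them.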